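The source may report more compounds than this note shows. Statements on the series, on what has been measured and on what is new or still open speak of the compounds shown alone.

Measured in a physicochemical assay for metabolic stability, read by HPLC, at pH 4.5, tested at 10 uM; a lower number here means that the compound disappears faster, a higher number that the compound lasts longer:

- Compound 1 `COc1nc2ccccc2n1C(=O)NCCCCc1ccccc1`: > 2 h, a limit
- Compound 2 `Cc1cccc(CNC(=O)n2cnc3ccccc32)c1`: > 2 h, a limit
- Compound 3 `CCCCCCNC(=O)n1cnc2ccccc21`: > 2 h, a limit

Among the measured compounds shown here, none of these three entries is an actual number, so the set contains no measured half-life and no ranking of the compounds. Compound 2 stands at > 2 h, which is a limit of this assay. The whole set reads the same way: the limit of > 2 h in this assay, at which 3 of the 3 values shown sit.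

Compound 4 `Cc1cccc(CNC(=O)n2c(N)nc3ccccc32)c1` departs from compound 2 in one place, with amino in place of hydrogen on an aromatic carbon. That carbon lies in a five-membered aromatic ring, between two ring nitrogen atoms and next to the ring atom that bears a large group. For the measured compounds named here, no pair of measured compounds shows what this change does, so the data offer no measured step to carry over.

The expectation therefore rests on compound 2 alone, with its > 2 h, a limit. No shift in either direction beyond the usual scatter is expected in this assay, and the result may again be only a limit. The expected change is a step that the limit leaves unreadable from compound 2 to compound 4. For compound 4 the estimated half-life is 2.5 h, with an expected range from 1 h to 6 h.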

Compound 4, half-life: 0.45 h
Estimate against measurement, compound 4: 5.6-fold (0.74 log units) above; measured number outside the range, below it.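

In this assay, amino in place of hydrogen on an aromatic carbon, between two ring nitrogen atoms and next to the ring atom that bears a large group, gives an at least 4.4-fold lower number from compound 2 to compound 4 (0.64 log units; beyond the scatter), which shows that a single change at this carbon can shorten the half-life. Among the compounds shown here, compound 4 is the only one of the four compounds whose half-life reads as a number, while the others share one limit: the limit of > 2 h in this assay, at which 3 of the 4 values shown sit. The value of compound 2 is only a limit, and the full size of the step therefore remains unknown, although the part that can be read already lies beyond the usual scatter.

What remains open is whether a methyl group, a dimethylamino group or an acetylamino group on the same carbon would shorten the half-life as amino does, and the compounds shown give no reason for the change. For the compounds shown here, it is also open whether amino at this carbon would bring the same drop with the hexyl chain of compound 3 or with a longer chain in place of the one in compound 4.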